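A few compounds are considered here, and "the series" means these few. Any claim that something is new, unique, unknown or untested is made for them only; others in the source may bear on it.

Working notes on the series. In a functional assay on MCF7 cells (Homo sapiens) for inhibition, read by MTT assay, with a stated time of 72 h, tested at 50 uM (on this read-out lower numbers stand for less inhibition of growth and higher numbers for more inhibition of growth at the one concentration tested), compound 1 (`C=CCc1cc(O)c(O)c(CN2CCC(C)CC2)c1`) gives 54.2%. Compound 2 (`C=CCc1ccc(OCc2cn(-c3ccc(C#N)cc3)nn2)c(O)c1`) gives 35.6%, the lower of the two numbers, and the gap between them lies beyond the usual scatter. Compound 3 (`C=CCc1ccc(OCc2cn(-c3ccccc3Cl)nn2)c(O)c1`) is not yet measured. It has 2-chlorophenyl in place of 4-cyanophenyl on an aromatic nitrogen. Among the measured compounds shown here, no measured pair differs at this place, and the data offer no direct guide. No shift beyond the scatter is expected in this assay. The expected change is a number 2.4 percentage points higher from compound 2 to compound 3 (within the scatter). Compound 3 is estimated at 38%, with an expected range of 22% to 55%.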

Compound 3, percent growth inhibition at one concentration: 34.3%
Estimate against measurement, compound 3: 3.7 percentage points above; the measured number falls inside the stated range.
By their numbers in this assay, from the lowest: compounds 3 and 2 (each within the scatter of the next); then compound 1.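

In this assay, this first step at the aromatic nitrogen of the five-membered ring is a number 1.3 percentage points lower from compound 2 to compound 3 (within the scatter), so the two aryl groups are not told apart at this place. Exchanging 4-cyanophenyl for 2-chlorophenyl therefore moves the number no further than the scatter, even though the nitrile leaves and a chlorine enters. Nothing available accounts for this result. Still open, as far as these compounds go, is whether a non-aromatic group on this nitrogen, such as a longer alkyl chain, or a phenyl ring carrying an amine or a carboxylic acid, would shift the number beyond the scatter.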